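A few compounds are considered here, and "the series" means these few. Any claim that something is new, unique, unknown or untested is made for them only; others in the source may bear on it.

Three compounds share one core and differ only in the group attached through the oxygen next to a carbonyl group. Compound 1 `N#C[Se]c1ccc(NC(=O)OCc2ccccc2)cc1` and compound 2 `N#C[Se]c1ccc(NC(=O)Oc2ccccc2)cc1` carry a phenyl there, directly in compound 2 and through one saturated chain carbon in compound 1, while compound 3 `CCCCCCOC(=O)Nc1ccc([Se]C#N)cc1` carries a hexyl chain. In an ADME assay on 184B5 cells (Homo sapiens) for cytotoxicity, read by MTT assay, with a stated time of 72 h (on this read-out lower numbers stand for stronger inhibition of growth and higher numbers for weaker inhibition of growth), compound 1 gives 21900 nM, compound 2 gives 22700 nM and compound 3 gives 20000 nM. The step of a 1.1-fold lower number from compound 1 to compound 3 (0.04 log units; within the scatter) and the step of a 1.1-fold lower number from compound 2 to compound 3 (0.05 log units; within the scatter) both stay within the scatter, so although compound 3 has the lowest of the three numbers, the three compounds cannot be told apart on these data.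

Compound 4 `CCCCOC(=O)Nc1ccc([Se]C#N)cc1` keeps the core and shortens the chain: hydrogen in place of ethyl on a saturated chain carbon, four bonds along the chain from an oxygen next to a carbonyl group. Among the measured compounds shown here, no measured step shortens a chain in this way, so nothing bears on it directly. The two steps that exist show that exchanging a phenyl for a hexyl on this side of the carbonyl hardly moved the number, which suggests the chain length matters little here. For compound 4 the expected step is a 1.1-fold higher number from compound 3 to compound 4 (0.02 log units; within the scatter), within the scatter. Compound 4 is therefore estimated at 21000 nM, with a range from 10000 nM to 45000 nM.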

Compound 4, concentration for total growth inhibition: 14500 nM
Compound 4: the middle estimate sits 1.4-fold (0.16 log units) above what was measured; the range from low to high includes it.
By their numbers in this assay, from the lowest: compounds 4, 3, 1 and 2 (each within the scatter of the next).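

Among the compounds shown here, compound 4 gives the first direct look at chain length on this oxygen, and in this assay cutting the ethyl end from the hexyl chain to leave a butyl chain gives a 1.4-fold lower number from compound 3 to compound 4 (0.14 log units; within the scatter), so on these data the two chain lengths cannot be told apart. The butyl chain also stays within the scatter when set against the phenyl-bearing compounds, with a 1.6-fold lower number from compound 2 to compound 4 (0.19 log units; within the scatter) and a 1.5-fold lower number from compound 1 to compound 4 (0.18 log units; within the scatter), so all four groups on this side of the carbonyl are so far compatible with a single level of growth inhibition, even though the steps involving compound 4 are larger than those seen among the first three compounds. No supporting data bear on these small differences.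

The compounds shown leave open whether a much shorter chain such as methyl or a longer one such as decyl would give a step beyond the scatter. On these data alone, it is also open whether an amine or a carboxylic acid at the end of the chain would move the number at all.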